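A Methoxy for a Nitro: What to Expect of Compound 3

The source may report more compounds than this note shows. Statements on the series, on what has been measured and on what is new or still open speak of the compounds shown alone.

Compound 1 `O=C(/C=C/c1ccccc1)c1ccc[nH]1`; in a functional assay on PC-3 cells (Homo sapiens) for inhibition, read by MTT assay, with a stated time of 48 h (a higher number here means a weaker inhibitor, a lower number a stronger inhibitor), compound 1 gives only a limit, > 100000 nM.
Compound 2 `O=C(/C=C/c1cccc([N+](=O)[O-])c1)c1ccc[nH]1`; in this assay compound 2 gives 23000 nM.
Compound 3 `COc1cccc(/C=C/C(=O)c2ccc[nH]2)c1`; not yet measured.

For the measured compounds named here, compound 2 holds the only number in this assay. Compound 1 sits at the limit of > 100000 nM in this assay, at which 1 of the 2 values shown sits. Compound 3 differs from compound 2 by methoxy in place of nitro on an aromatic carbon. Going by the values given here, the single measured step, an at least 4.3-fold lower number from compound 1 to compound 2 (0.63 log units; beyond the scatter), covers the nitro entering; its removal is part of the present change, so part of that gain is expected to be lost, while the methoxy itself has no measured counterpart here. Compound 3 is therefore estimated at 60000 nM, between 20000 nM and 150000 nM. The expected step is a 2.6-fold higher number from compound 2 to compound 3 (0.42 log units; beyond the scatter).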

Compound 3, half-maximal inhibitory concentration: 24000 nM
Compound 3: the middle estimate sits 2.5-fold (0.40 log units) above what was measured; the measured number falls inside the stated range.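

Methoxy and nitro could not be told apart at this aromatic carbon: in this assay the change is a 1.0-fold higher number from compound 2 to compound 3 (0.02 log units; within the scatter). Methoxy in place of hydrogen gives an at least 4.1-fold lower number from compound 1 to compound 3 (0.61 log units; beyond the scatter), so the gain seen earlier does not belong to nitro alone. Compound 1 gives only a limit, so the full size of that gain stays unknown: the limit of > 100000 nM in this assay, at which 1 of the 3 values shown sits.

Going by these compounds, whether an amine, a hydroxyl or a chlorine on this same carbon would match methoxy and nitro stays open. So does whether either group would hold its effect on another carbon of the ring.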